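The source may hold more compounds than are shown below. What is called first, only, known or untested is meant among the compounds shown, and "the series" means these compounds.

Among the compounds with values here, in a functional assay on HEK293 cells for agonist activity at D(4) dopamine receptor (Homo sapiens), read by FLIPR (on this read-out lower numbers stand for smaller maximal responses and higher numbers for larger maximal responses), the three compounds measured so far reach clearly different maximal responses. Compound 1, `Cc1cccc(NC(=O)CN2CCC(c3cccc(F)c3)CC2)c1`, gives 40% and stands lowest of the three. Compound 2, `Cc1cc(NC(=O)CN2CCC(c3cccc[n+]3[O-])CC2)ccc1F`, gives 75%, a response beyond the scatter above compound 1. Compound 3, `CCOc1cccc(C(=O)NCN2CCC(c3cccc[n+]3[O-])CC2)c1`, gives 54%, also beyond the scatter above compound 1 and the nearer of the two. Within the data shown here, compounds 2 and 3 differ from compound 1 in more than one place, so no single step between measured compounds is available to guide the next change.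

The compound not yet measured is compound 4, `Cc1cccc(NC(=O)CN2CCC(c3ccccc3C#N)CC2)c1`. It differs from compound 1 in one place: 2-cyanophenyl in place of 3-fluorophenyl on a saturated ring carbon. The group that enters carries a nitrile and brings one hydrogen-bond acceptor where the group that leaves had none.

Without a measured step of this kind to lean on, the expectation for this change is modest: a small rise is expected, within or only just beyond the scatter, and a fall would not be surprising. The step from compound 1 to compound 4 is estimated as a number 10 percentage points higher from compound 1 to compound 4 (within the scatter). Compound 4 is expected to give 50% in this assay, with a range from 25% to 75%.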

Compound 4, largest response reached (reported as efficacy), in percent of the reference or control that the assay uses: 71%
Compound 4: middle estimate off by 21 percentage points, on the low side; the measured number falls inside the stated range.
By their numbers in this assay, from the lowest: compound 1; then compound 3; then compounds 4 and 2 (each within the scatter of the next).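

Read in this assay the swap of 3-fluorophenyl for 2-cyanophenyl on a saturated ring carbon gives a number 31 percentage points higher from compound 1 to compound 4 (beyond the scatter) while the rest of compound 1 stays the same. Within the data shown here, this is the first step here that changes only one place, and it shows that the group at this position can by itself shift the maximal response by a large amount. No measurement shown here accounts for the size of this step.

The step replaces fluorine with a nitrile and also changes the number in the group's name from 3 to 2, so it cannot tell which of the two differences matters or whether both are needed. Compounds carrying 3-cyanophenyl, 2-fluorophenyl or plain phenyl on the same core would separate these differences, and 2-methoxyphenyl would show whether the rise extends to a group other than the nitrile.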